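Nitrile for ethynyl on the N-aryl ring

A few compounds are considered here, and "the series" means these few. Any claim that something is new, unique, unknown or untested is made for them only; others in the source may bear on it.

Measured so far in an assay on isolated protein for inhibition of Retinaldehyde dehydrogenase 3 (Homo sapiens); a lower number here means a stronger inhibitor, a higher number a weaker inhibitor:
compound 1 `CC(Sc1nc2c(cnn2C)c(=O)n1-c1ccccc1)c1cccc(F)c1`, 128 nM
compound 2 `C#Cc1ccc(-n2c(SC(C)c3ccccc3)nc3c(cnn3C)c2=O)cc1`, 520 nM
compound 3 `Cn1ncc2c(=O)n(-c3ccccc3)c(SCc3cccc(F)c3)cc21`, 140 nM

Compound 2 stands at the highest number of the three. Compound 3 gives 140 nM and compound 1 gives 128 nM, and both gaps to compound 2 lie beyond the usual scatter. Compound 4 `CC(Sc1nc2c(cnn2C)c(=O)n1-c1ccc(C#N)cc1)c1ccccc1` has not yet been measured in this assay. It differs from compound 2 in one place: cyano in place of ethynyl on an aromatic carbon. Among the measured compounds shown here, no step between measured compounds that differ in a single place is available, so the exchange cannot be calibrated from the series. Compound 4 is estimated at 320 nM, with a range of 130 nM to 800 nM. The step of a 1.6-fold lower number from compound 2 to compound 4 (0.21 log units; within the scatter) is expected to be small, towards a lower number, and probably within the scatter.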

Compound 4, half-maximal inhibitory concentration: 200 nM
The estimate for compound 4 lay 1.6-fold (0.20 log units) above the measured number; the measured number falls inside the stated range.
By their numbers in this assay, from the lowest: compounds 1, 3 and 4 (each within the scatter of the next); then compound 2.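

In this assay, among the compounds shown here, the exchange of 4-ethynylphenyl for 4-cyanophenyl provides the first single-place step, a 2.6-fold lower number from compound 2 to compound 4 (0.41 log units; beyond the scatter), so the number responds modestly to this change on an aromatic carbon para to a large group. With the heavy-atom count unchanged, the exchange adds one hydrogen-bond acceptor, but one step cannot link that difference to the lower number. No measured evidence bears on the origin of this step.

Going by these compounds, how an amine, a carboxylic acid or a methoxy group at this position would compare with cyano remains open. Also open, on these data alone, is whether the exchange gives a similar step with a different group on the sulfur.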